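The source may hold more compounds than are shown below. What is called first, only, known or untested is meant among the compounds shown, and "the series" means these compounds.

Measured compounds:
Compound 1, `CCn1c(C(=O)NCCCN(C)C)ccc1C(CC)(CC)c1ccc(OCC(O)C(C)(C)C)c(C)c1`: 470 nM
Compound 2, `C#CCNC(=O)c1ccc(C(CC)(CC)c2ccc(OCC(O)C(C)(C)C)c(C)c2)n1CC`: 4400 nM
Compound 3, `C=CCN(C)C(=O)c1ccc(C(CC)(CC)c2ccc(OCC(O)C(C)(C)C)c(C)c2)n1CC`: 6300 nM

In an ADME assay on L02 cells (Homo sapiens) for cytotoxicity, read by MTT assay, with a stated time of 48 h (on this read-out higher numbers stand for weaker inhibition and lower numbers for stronger inhibition), compound 1 gives the lowest of the three numbers, with compound 2 and compound 3 both lying well above it. The unmeasured compound 4, `CCn1c(C(=O)OCc2ccc(F)cc2)ccc1C(CC)(CC)c1ccc(OCC(O)C(C)(C)C)c(C)c1`, shares the core of compound 1 and differs from it in one place: (4-fluorobenzyl)oxy in place of (3-(dimethylamino)propyl)amino on a carbonyl carbon. Going by the values given here, two measured steps bear on this change, since each also removes the (3-(dimethylamino)propyl)amino group from the carbonyl carbon. The step of a 9.4-fold higher number from compound 1 to compound 2 (0.97 log units; beyond the scatter) and the step of a 13-fold higher number from compound 1 to compound 3 (1.13 log units; beyond the scatter) both lie beyond the scatter and point the same way. Between compound 2 and compound 3 the step of a 1.4-fold higher number from compound 2 to compound 3 (0.16 log units; within the scatter) stays within the scatter, so the two replacements look much alike in this assay. The step to compound 4 is therefore expected to be upward in this assay, of comparable size: an estimated 11-fold higher number from compound 1 to compound 4 (1.03 log units; beyond the scatter). For compound 4 the expected value in this assay is 5000 nM, within a range from 1500 nM to 16000 nM.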

Compound 4, half-maximal inhibitory concentration: 14900 nM
Estimate against measurement, compound 4: 3.0-fold (0.47 log units) below; the range from low to high includes it.
By their numbers in this assay, from the lowest: compound 1; then compounds 2 and 3 (each within the scatter of the next); then compound 4.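

In this assay the (4-fluorobenzyl)oxy group gives a 32-fold higher number from compound 1 to compound 4 (1.50 log units; beyond the scatter) and so moves further from compound 1 than either earlier replacement on this carbonyl carbon. Replacements of (3-(dimethylamino)propyl)amino at this place therefore do not all settle at one level, as compounds 2 and 3 alone had suggested: the result adds a 3.4-fold higher number from compound 2 to compound 4 (0.53 log units; beyond the scatter) and also a 2.4-fold higher number from compound 3 to compound 4 (0.37 log units; beyond the scatter) to the picture, and compound 1 keeps the lowest number of the four. Nothing shown here gives a reason for these steps.

The change to compound 4 replaces the amide-type nitrogen with oxygen and brings in an aromatic ring at once, and a 4-fluorobenzylamino group on the same carbonyl carbon would be needed to tell these apart. From the compounds shown here alone, it also remains open whether a shorter (2-(dimethylamino)ethyl)amino chain or a free carboxylic acid at this place would give a number nearer compound 1 or nearer compound 4.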